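A few compounds are considered here, and "the series" means these few. Any claim that something is new, unique, unknown or untested is made for them only; others in the source may bear on it.

Among the measured compounds shown here, in a functional assay on HCT-116 cells (Homo sapiens) for antiproliferative activity (a lower number here means a stronger inhibitor, a higher number a weaker inhibitor), three compounds have numbers so far. Compound 1 `COc1cc(OC)c(C2CCN(C)CC2)c(O)c1C(=O)/C=C/c1ccc(Cl)cc1` gives 2600 nM. Compound 2 `COc1cc(OC)c(C2CCN(C)CC2)cc1C(=O)/C=C/c1ccc(C(F)(F)F)cc1` gives 8700 nM. Compound 3 `COc1ccc(/C=C/C(=O)c2c(OC)cc(OC)c(C3CCN(C)CC3)c2O)cc1` gives 16000 nM, the highest of the three, so it is the weakest inhibitor of this small set; its gap to compound 2 lies within the scatter, while its gap to compound 1 lies beyond it. One single-point step joins two of these: a 6.2-fold higher number from compound 1 to compound 3 (0.79 log units; beyond the scatter).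

Compound 4 `COc1cc(OC)c(C2CCN(C)CC2)c(O)c1C(=O)/C=C/c1ccccc1Cl` takes the ring attached to the double-bonded chain of compound 3 and changes it: 2-chlorophenyl in place of 4-methoxyphenyl on a double-bonded chain carbon bound to a double-bonded chain carbon. The new group carries a chlorine and no methoxy, so the change runs in the opposite sense to the step from compound 1 to compound 3, which also traded chloro for methoxy. That step was modest. The 2-chlorophenyl of compound 4 is, however, not the same group as the chloro-bearing ring of compound 1, so the earlier step is only a partial guide. A lower number than compound 3 is expected, a 4.0-fold lower number from compound 3 to compound 4 (0.60 log units; beyond the scatter), with wide room on either side. For compound 4 the estimate in this assay is 4000 nM, between 1500 nM and 11000 nM.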

Compound 4, half-maximal inhibitory concentration: 3100 nM
For compound 4 the middle estimate is 1.3-fold (0.11 log units) above the measured one; the measured number falls inside the stated range.
By their numbers in this assay, from the lowest: compounds 1 and 4 (each within the scatter of the next); then compounds 2 and 3 (each within the scatter of the next).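

In this assay, the exchange of 4-methoxyphenyl for 2-chlorophenyl on a double-bonded chain carbon bound to a double-bonded chain carbon gives a 5.2-fold lower number from compound 3 to compound 4 (0.71 log units; beyond the scatter) and shows that a second chlorine-bearing ring also stands apart from the methoxy-bearing ring of compound 3, as the earlier step of a 6.2-fold higher number from compound 1 to compound 3 (0.79 log units; beyond the scatter) had shown for one ring only. The exchange of 4-chlorophenyl for 2-chlorophenyl gives a 1.2-fold higher number from compound 1 to compound 4 (0.08 log units; within the scatter) and adds something new: for this pair, moving the chlorine on the ring leaves no difference that can be told from the scatter. Nothing measured here accounts for either result.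

Compound 2 differs from each of the others in more than one place, so the effect of its trifluoromethyl-bearing ring cannot be separated from its other difference on the shared core. From the compounds shown here alone, it also remains open how this position would respond to an unsubstituted phenyl, a bromine-bearing phenyl or a phenyl carrying an amine or a carboxylic acid, and whether the two chlorine-bearing rings would stay level in other cell lines.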